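The compounds below may be only part of what the source reports. "The series", "measured", "known", "first", "only" and "open" are said of these compounds alone.

Compound 1 `O=C(CSc1nc2c(c(=O)n1-c1ccccc1)SCC2)Nc1nc2ccc(Cl)cc2s1` and compound 2 `COc1ccccc1-n1c(SCC(=O)Nc2nc3ccc(Cl)cc3s2)nc2c(c1=O)SCC2` share one core. In an assay on L cells for inhibition of Protein-serine O-palmitoleoyltransferase porcupine (Mus musculus), read by reporter gene assay, with a stated time of 24 h (a lower number here means that less compound is needed, a higher number that more compound is needed for the effect), compound 1 gives 40 nM, and compound 2 gives 50 nM; compound 2 stands at the higher of these two numbers, yet its gap to compound 1 lies within the scatter. For the measured compounds named here, the single measured step, a 1.3-fold higher number from compound 1 to compound 2 (0.10 log units; within the scatter), is within the scatter. Compound 3 `COc1ccc(-n2c(SCC(=O)Nc3nc4ccc(Cl)cc4s3)nc3c(c2=O)SCC3)cc1` differs from compound 2 by 4-methoxyphenyl in place of 2-methoxyphenyl on an aromatic nitrogen. Going by the values given here, no measured step covers moving a methoxy in this way; because the only comparison, a 1.3-fold higher number from compound 1 to compound 2 (0.10 log units; within the scatter), changed little, only a small step is expected, no change at the digits printed from compound 2 to compound 3 (within the scatter). Compound 3 is estimated at 50 nM, between 18 nM and 140 nM.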

Compound 3, half-maximal effective concentration: 35 nM
The estimate for compound 3 lay 1.4-fold (0.15 log units) above the measured number, within the range that was stated.
By their numbers in this assay, from the lowest: compounds 3, 1 and 2 (each within the scatter of the next).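

In this assay, 4-methoxyphenyl in place of 2-methoxyphenyl on the aromatic nitrogen gives a 1.4-fold lower number from compound 2 to compound 3 (0.15 log units; within the scatter) and methoxy in place of hydrogen on an aromatic carbon gives a 1.1-fold lower number from compound 1 to compound 3 (0.06 log units; within the scatter) as a second step. Both steps lie within the scatter, so neither the presence of a methoxy nor the change from 2-methoxyphenyl to 4-methoxyphenyl separates these three compounds. No evidence available here bears on the reason for this result.

The compounds shown leave open whether 3-methoxyphenyl would fall in the same range. They also leave open whether an amine, a carboxylic acid or a longer alkoxy chain in place of the methoxy would move the number beyond the scatter.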